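Solubility notes on the aminoquinoline series

The compounds below may be only part of what the source reports. "The series", "measured", "known", "first", "only" and "open" are said of these compounds alone.

Measured so far:
compound 1 `Cc1cc(C)cc(Cc2ccc3c(NCCCNCc4ccco4)ccnc3c2)c1`: 4200 nM
compound 2 `COc1cccc(CNCCCNc2ccnc3cc(Cc4cc(C)cc(C)c4)ccc23)c1O`: 4200 nM
compound 3 `COc1ccc(F)cc1CNCCCNc1ccnc2cc(Cc3cc(C)cc(C)c3)ccc12`: 4200 nM

In a physicochemical assay for solubility, with a stated time of 18 h, at pH 7.4 (on this read-out lower numbers stand for lower solubility and higher numbers for higher solubility), compound 2 stands level with compounds 1 and 3. The steps of no change at the digits printed from compound 1 to compound 2 (within the scatter), no change at the digits printed from compound 1 to compound 3 (within the scatter) and no change at the digits printed from compound 2 to compound 3 (within the scatter) all lie within the scatter; each of them alters only the group on the saturated chain carbon bound to the amine nitrogen and leaves the rest of the core untouched.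

Compound 4 `CCC(CC)c1ccc2c(NCCCNCc3cccc(OC)c3O)ccnc2c1` is not yet measured. Its change from compound 2 is pentan-3-yl in place of 3,5-dimethylbenzyl on an aromatic carbon. Among the compounds with values here, no measured step touches this part of the core, so nothing here tells how this assay responds to it; the three known values only show the series sitting at one level. With a smaller, ring-free group entering, a modest rise is expected but not a large one. Compound 4 is therefore estimated at 7000 nM, range 2500 nM to 20000 nM, a step of a 1.7-fold higher number from compound 2 to compound 4 (0.22 log units; within the scatter) that is expected to stay near or just beyond the scatter.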

Compound 4, solubility: 4200 nM
The estimate for compound 4 lay 1.7-fold (0.22 log units) above the measured number; the measured number falls inside the stated range.
By their numbers in this assay, from the lowest: compounds 1, 2, 3 and 4 (each within the scatter of the next).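

In this assay, within the data shown here, the first step at this aromatic carbon reads no change at the digits printed from compound 2 to compound 4 (within the scatter), so the position tolerates pentan-3-yl in place of 3,5-dimethylbenzyl. Among these compounds, the read-out thus holds even with the six-membered aromatic ring gone and the group down from 9 heavy atoms to 5, whereas the earlier steps touched only the saturated chain carbon. Nothing available bears on why the number holds.

As far as these compounds go, whether a carboxylic acid or an amine on this aromatic carbon would shift the read-out stays open. So does whether pentan-3-yl gives the same outcome with furan-2-yl on the chain carbon.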